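The compounds below may be only part of what the source reports. "The series", "measured", "known", "first", "only" and "open" are said of these compounds alone.

Compound 2 `CCCCCCCCCCCCCCCC1(O)CC(=O)c2c(O)cc(OCOC)cc2O1` is the saturated member of this small set. For the measured compounds named here, in a functional assay on MDA-MB-231 cells (Homo sapiens) for antiproliferative activity, read by MTT assay (a higher number here means a weaker inhibitor, a lower number a stronger inhibitor), compound 2 gives > 87000 nM, which is a limit of the assay rather than a number, and it is the one value of the three that sits at that ceiling (the limit of > 87000 nM in this assay, at which 1 of the 3 values shown sits). Compound 4 `CCCCCCCCCCCCCCCC1(O)CC(=O)c2c(O)cc(O)cc2O1` differs from it in one place: hydrogen in place of methoxymethyl on an oxygen on an aromatic ring. Going by the values given here, no measured step changes that oxygen while the chain stays saturated, so the step to compound 4 has no direct precedent. Among the compounds with values here, the only measured step nearby is the chain change from compound 2 to compound 3 `CCCC/C=C\CCCCCCCCCC1(O)CC(=O)c2c(O)cc(OCOC)cc2O1`, which gives an at least 2.0-fold lower number from compound 2 to compound 3 (0.30 log units; that floor lies within the scatter); in this assay compound 3 gives 42800 nM. Compound 1 `CCCCC/C=C\C/C=C\CCCCCCCC1(O)CC(=O)c2c(O)cc(O)cc2O1` carries the free hydroxy together with a doubly unsaturated chain, and in this assay compound 1 gives 6790 nM; it differs from compound 3 in two places, so the two values only show that the free-hydroxy diene sits far lower than the methoxymethyl monoene. Compound 4 is therefore expected to leave the limit but to remain well above compound 1, since its chain is saturated; the estimated step is an at least 2.1-fold lower number from compound 2 to compound 4 (0.33 log units; beyond the scatter). For compound 4 the expected value in this assay is 40000 nM, with a range from 10000 nM to 150000 nM.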

Compound 4, half-maximal inhibitory concentration: 6790 nM
Estimate against measurement, compound 4: 5.9-fold (0.77 log units) above; measured number below the stated range.
By their numbers in this assay, from the lowest: compounds 1 and 4 (each within the scatter of the next); then compound 3. At a limit, above all of these: compound 2.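

For the compounds shown here, replacing methoxymethyl with hydrogen on the oxygen on the aromatic ring gives the first measured change at this position with the chain held saturated, and in this assay it is large: an at least 12-fold lower number from compound 2 to compound 4 (1.10 log units; beyond the scatter) while the chain stays exactly as it was. Compound 2 stands at a limit of the assay, so this step gives only a floor for the change: the limit of > 87000 nM in this assay, at which 1 of the 4 values shown sits. With the hydroxy free, the chain makes no visible difference in this pair, since octyl in place of deca-1,4-dien-1-yl gives no change at the digits printed from compound 1 to compound 4 (within the scatter) and the two unsaturations of compound 1 therefore add nothing that this read-out can detect.

The compounds shown carry only hydrogen or methoxymethyl on that oxygen, so they cannot tell whether the free hydroxy is required or whether a small methyl ether or an acetyl ester there would serve as well. As far as these compounds go, it also stays open whether the chain remains as indifferent with methoxymethyl on the oxygen, and whether a shorter chain or one ending in a carboxylic acid would move the value.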